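The source may report more compounds than this note shows. Statements on the series, on what has been measured and on what is new or still open speak of the compounds shown alone.

Three compounds built on one shared core have been examined in a functional assay on MDA-MB-435 cells (Homo sapiens) for cytotoxicity, read by MTT assay, with a stated time of 72 h; a higher number here means a weaker inhibitor, a lower number a stronger inhibitor. Compound 1 `C[C@@H](Nc1c(C(=O)NCc2ccc(F)cc2)nc(Br)c2cccnc12)c1ccccc1` returns only a limit in this assay, > 20000 nM. Compound 2 `COC(=O)c1nc(Br)c2cccnc2c1N[C@H]1CC[C@H](N)CC1` likewise returns only a limit in this assay, > 20000 nM. Among the measured compounds shown here, compound 3 `N[C@H]1CC[C@H](NC(=O)c2nc(Br)c3cccnc3c2NCc2ccc(F)cc2)CC1` is the one member of the set that gives a number in this assay, 6600 nM. For the measured compounds named here, compound 1 therefore stands at the limit of > 20000 nM in this assay, at which 2 of the 3 values shown sit, and the set contains no pair of measured compounds that differ in a single place.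

The step under consideration runs from compound 1 to compound 4 `CN(C)CCCNc1c(C(=O)NCc2ccc(F)cc2)nc(Br)c2cccnc12`, which has not yet been measured in this assay. The change is 3-(dimethylamino)propyl in place of 1-phenylethyl on a nitrogen on an aromatic ring. Going by the values given here, no measured pair isolates this change, so its size in this assay cannot be read from the compounds at hand. Among the compounds with values here, compound 3, the only compound here with a numerical value of 6600 nM, differs from compound 1 in more than one place, so it cannot be used to size the present change either. Compound 4 is consequently expected to stay in the weak region, with a fair chance of again yielding only a limit, and its estimated value is 14000 nM, within a range of 4000 nM to 40000 nM. The expected step is an at least 1.4-fold lower number from compound 1 to compound 4 (0.15 log units; that floor lies within the scatter).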

Compound 4, half-maximal inhibitory concentration: 7000 nM
Estimate against measurement, compound 4: 2.0-fold (0.30 log units) above; measured number inside the range.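

In this assay, among the compounds shown here, this result gives the first comparison in the set that changes a single place on the shared core, and it reads as an at least 2.8-fold lower number from compound 1 to compound 4 (0.45 log units; beyond the scatter). It shows that the substituent on a nitrogen on an aromatic ring can by itself move a compound off the limit and onto a measurable value, with 3-(dimethylamino)propyl in place of 1-phenylethyl and the rest of the molecule unchanged. The true size of the step remains unknown and only its floor can be given, because compound 1 is held at a limit and not at a number: the limit of > 20000 nM in this assay, at which 2 of the 4 values shown sit.

The compounds shown do not separate what the entering dimethylamino nitrogen contributes from what follows the departure of the aromatic ring and the defined stereocentre of 1-phenylethyl. A plain butyl chain, a shorter 2-(dimethylamino)ethyl chain or a primary aminopropyl chain on the same nitrogen would begin to pull these apart, and would also show whether the chain length matters at this position.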